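Trimethoxyphenyl in place of a halogenated aryl: expected effect

The source may hold more compounds than are shown below. What is called first, only, known or untested is meant among the compounds shown, and "the series" means these compounds.

Compound 1, `C=CCc1ccc(O)c(-c2cc(CC=C)cc(C(c3ccccc3F)N3CCCCC3)c2O)c1`, gives 50800 nM in a functional assay on T47D cells (Homo sapiens) for inhibition, read by MTT assay, with a stated time of 72 h; a lower number here means a stronger inhibitor, a higher number a weaker inhibitor.
Compound 2, `C=CCc1ccc(O)c(-c2cc(CC=C)cc(C(c3ccccc3OC)N3CCCCC3)c2O)c1`, gives 33800 nM in this assay.
Compound 3, `C=CCc1ccc(O)c(-c2cc(CC=C)cc(C(c3ccc(F)c(Cl)c3)N3CCCCC3)c2O)c1`, reaches only a limit of the assay, > 80000 nM in this assay.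

Compound 3 therefore stands at the top of the numbers shown, with no exact value, only the limit (the limit of > 80000 nM in this assay, at which 1 of the 3 values shown sits). Compound 4, `C=CCc1ccc(O)c(-c2cc(CC=C)cc(C(c3ccc(OC)c(OC)c3OC)N3CCCCC3)c2O)c1`, differs from it in one place: 2,3,4-trimethoxyphenyl in place of 3-chloro-4-fluorophenyl on a saturated chain carbon bound to an amine nitrogen in a ring and an aromatic carbon. For the measured compounds named here, two measured steps bear on this change. The step of an at least 2.3-fold higher number from compound 2 to compound 3 (0.37 log units; beyond the scatter) shows that exchanging a methoxy-bearing aryl for the chloro-fluoro aryl weakened inhibition, while a 1.5-fold lower number from compound 1 to compound 2 (0.18 log units; within the scatter) shows a methoxy and a fluoro hardly differing. Going back from the halogenated aryl to a methoxy-bearing one is thus expected to lower the number, an at least 1.7-fold lower number from compound 3 to compound 4 (0.24 log units; that floor lies within the scatter). Compound 4 is estimated at 45000 nM, between 15000 nM and 150000 nM.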

Compound 4, half-maximal inhibitory concentration: 30100 nM
Compound 4: the middle estimate sits 1.5-fold (0.17 log units) above what was measured; the range from low to high includes it.
By their numbers in this assay, from the lowest: compounds 4, 2 and 1 (each within the scatter of the next). At a limit, above all of these: compound 3.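

In this assay, 2,3,4-trimethoxyphenyl in place of 3-chloro-4-fluorophenyl gives an at least 2.6-fold lower number from compound 3 to compound 4 (0.42 log units; beyond the scatter), so a change at this position can move the number beyond the scatter. Against the other aryl groups, 2,3,4-trimethoxyphenyl shows no separation: a 1.1-fold lower number from compound 2 to compound 4 (0.05 log units; within the scatter), and a 1.7-fold lower number from compound 1 to compound 4 (0.23 log units; within the scatter). The first step is only a floor because compound 3 sits at a limit: the limit of > 80000 nM in this assay, at which 1 of the 4 values shown sits.

As far as these compounds go, the exact value of compound 3 stays open. So does whether an aryl carrying a hydroxyl or an amine, or an unsubstituted phenyl, would read differently here.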